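One Aromatic Group Changes on a Carbonyl Carbon

This account rests on a few compounds, and the source may have more. Where it says the series, first, only, none or still open, it means among the compounds named here.

Among the compounds with values here, only two compounds sharing one core have numbers so far. In a functional assay on MDA-MB-231 cells (Homo sapiens) for antiproliferative activity, read by MTT assay, with a stated time of 72 h (a higher number here means a weaker inhibitor, a lower number a stronger inhibitor), compound 1 `CC1=CC[C@H]2[C@H](CC[C@]2(C)O)C(C)(C)[C@@H]1CC[C@H]1[C@]2(C)CC[C@H](OC(=O)c3ccccc3)C(C)(C)O[C@H]2CC[C@@]1(C)O` gives 16100 nM and compound 2 `CC1=CC[C@H]2[C@H](CC[C@]2(C)O)C(C)(C)[C@@H]1CC[C@H]1[C@]2(C)CC[C@H](OC(=O)c3ccc(Cl)c(Cl)c3)C(C)(C)O[C@H]2CC[C@@]1(C)O` gives 8100 nM as its reading. These two values sit within the scatter of each other, so compound 2 cannot yet be separated from compound 1.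

Compound 3 `CC1=CC[C@H]2[C@H](CC[C@]2(C)O)C(C)(C)[C@@H]1CC[C@H]1[C@]2(C)CC[C@H](OC(=O)c3ccccc3F)C(C)(C)O[C@H]2CC[C@@]1(C)O` keeps the shared core and differs from compound 2 by one group, counted as 2-fluorophenyl in place of 3,4-dichlorophenyl on a carbonyl carbon and put in words as 2-fluorophenyl in place of 3,4-dichlorophenyl on a carbonyl carbon. Within the data shown here, one measured step bears on this change, because the swap at that same place gave a 2.0-fold lower number from compound 1 to compound 2 (0.30 log units; within the scatter) as its size. Among the measured compounds shown here, that is thin evidence, since no compound with fluorine has been measured yet. No step beyond the scatter is therefore expected in this assay for this change, and no direction can be firmly expected. The estimated move is a 1.4-fold higher number from compound 2 to compound 3 (0.13 log units; within the scatter) and nothing more. Compound 3 is expected to read about 11000 nM with 5500 nM to 22000 nM as its estimated range.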

Compound 3, half-maximal inhibitory concentration: 28700 nM
For compound 3 the middle estimate is 2.6-fold (0.42 log units) below the measured one; measured number above the stated range.
By their numbers in this assay, from the lowest: compounds 2, 1 and 3 (each within the scatter of the next, the first and the last beyond it).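

In this assay, within the data shown here, a 3.5-fold higher number from compound 2 to compound 3 (0.55 log units; beyond the scatter) is the first step at this position to lie beyond the scatter, so the aromatic group on the carbonyl carbon can shift the reading measurably. That separation holds only between the two halogen-bearing compounds: adding a fluoro gives a 1.8-fold higher number from compound 1 to compound 3 (0.25 log units; within the scatter), and the earlier change to 3,4-dichlorophenyl gives a 2.0-fold lower number from compound 1 to compound 2 (0.30 log units; within the scatter), both within the scatter, so neither compound can yet be told apart from the unsubstituted phenyl of compound 1. No measurement shown here accounts for the gap between the 3,4-dichlorophenyl and 2-fluorophenyl groups.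

The 3,4-dichlorophenyl and 2-fluorophenyl groups differ in the kind of halogen, the number of halogens and where they sit, so these compounds leave open which of those differences carries the step. Also open, from the compounds shown here alone, is how this position responds to a group without halogen, such as a methoxy group on the aromatic ring, an amine on that ring, or a saturated cyclohexyl ring in place of the aromatic one.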